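Diethylamino for dimethylamino on a second quinazoline-type core

The source may hold more compounds than are shown below. What is called first, only, known or untested is meant among the compounds shown, and "the series" means these compounds.

Measured compounds:
compound 1, `CN(C)C/C=C/C(=O)Nc1cc2c(N3CCc4ccccc43)ncnc2cc1O[C@@H]1CCOC1`, 1340 nM
compound 2, `CCN(CC)C/C=C/C(=O)Nc1cc2c(N3CCc4ccccc43)ncnc2cc1O[C@@H]1CCOC1`, 4980 nM
compound 3, `COc1cc2ncnc(N3CCCc4ccccc43)c2cc1NC(=O)/C=C/CN(C)C`, 1770 nM

Of the compounds shown here, three have been measured in a functional assay on MCF7 cells (Homo sapiens) for antiproliferative activity, read by MTT assay, with a stated time of 72 h; a lower number here means a stronger inhibitor, a higher number a weaker inhibitor. Compound 1 `CN(C)C/C=C/C(=O)Nc1cc2c(N3CCc4ccccc43)ncnc2cc1O[C@@H]1CCOC1` gives 1340 nM in this assay, and compound 2 `CCN(CC)C/C=C/C(=O)Nc1cc2c(N3CCc4ccccc43)ncnc2cc1O[C@@H]1CCOC1` gives 4980 nM. The two differ in one place: diethylamino in place of dimethylamino on a saturated chain carbon bound to a double-bonded chain carbon. That change produced a step of a 3.7-fold higher number from compound 1 to compound 2 (0.57 log units; beyond the scatter), so the diethylamino analogue is the weaker of the pair.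

Compound 3 `COc1cc2ncnc(N3CCCc4ccccc43)c2cc1NC(=O)/C=C/CN(C)C` carries a different core and gives 1770 nM. How the core of compound 3 differs from the core of compound 1 is not broken down here. Compound 3 and compound 1 lie within the scatter of each other, while compound 3 sits below compound 2 by a gap that is beyond it.

Compound 4 `CCN(CC)C/C=C/C(=O)Nc1cc2c(N3CCCc4ccccc43)ncnc2cc1OC` is the unmeasured partner of compound 3 and differs from it in one place: diethylamino in place of dimethylamino on a saturated chain carbon bound to a double-bonded chain carbon. The place is the same as in the earlier pair, so this is the same change, made on the core of compound 3. Because the step of a 3.7-fold higher number from compound 1 to compound 2 (0.57 log units; beyond the scatter) was modest and beyond the scatter, a step of similar size is expected here, a 3.4-fold higher number from compound 3 to compound 4 (0.53 log units; beyond the scatter). For the measured compounds named here, this rests on one pair only; no second pair on either core confirms it. Compound 4 is therefore expected to give about 6000 nM, within a range of 2500 nM to 15000 nM.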

Compound 4, half-maximal inhibitory concentration: 5310 nM
Compound 4: the middle estimate sits 1.1-fold (0.05 log units) above what was measured; the measured number falls inside the stated range.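

In this assay, putting diethylamino in place of dimethylamino on the core of compound 3 gives a 3.0-fold higher number from compound 3 to compound 4 (0.48 log units; beyond the scatter) and again leaves the diethylamino analogue as the weaker of its pair. Set beside the earlier step, the change carries from one core to the other in the same direction and at a matching size: the same change on two cores in this assay, a 3.7-fold higher number (0.57 log units; beyond the scatter) from compound 1 to compound 2 and a 3.0-fold higher number (0.48 log units; beyond the scatter) from compound 3 to compound 4, 1.2-fold (0.09 log units) apart, within the scatter of two such steps. This shows that the penalty for the diethylamino group held on both cores shown, but it rests on a single pair per core in a single cell assay, so it does not establish that the step would hold on a third core or in another assay, and it does not explain why the number rises.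

The compounds shown leave open how the amine itself governs the result, since only dimethylamino and diethylamino appear on the saturated chain carbon, and a cyclic amine such as piperidine or morpholine, or a longer chain carrying the amine, could follow the same trend or break it. They also leave open which of the differences between the two cores, if any, bears on the values, since the two cores differ in more than one place.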